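This account rests on a few compounds, and the source may have more. Where it says the series, first, only, none or still open, it means among the compounds named here.

Measured compounds:
Compound 1, `O=C(CCCCCCc1ccccc1)c1nc(-c2ccco2)no1`, gives 1 nM in an assay for inhibition of Fatty-acid amide hydrolase 1 (Rattus norvegicus), at pH 9.0; a higher number here means a weaker inhibitor, a lower number a stronger inhibitor.
Compound 2, `O=C(CCCCCCc1ccccc1)c1nc(-c2cccs2)no1`, gives 1.6 nM in this assay.
Compound 3, `O=C(CCCCCCc1ccccc1)c1nnc(-c2ccco2)s1`, gives 7.4 nM in this assay.

Compound 1 and compound 2 share a core and differ by thiophen-2-yl in place of furan-2-yl on an aromatic carbon. This change gave a 1.6-fold higher number from compound 1 to compound 2 (0.20 log units; within the scatter), so the two values are not told apart by this assay. Compound 3 carries a different core; how its core differs from that of compound 1 is not broken down here. Its value in this assay is the highest of the three, and what the numbers show is that compound 3 sits beyond the scatter above both compound 1 and compound 2.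

Compound 4, `O=C(CCCCCCc1ccccc1)c1nnc(-c2cccs2)s1`, has not yet been measured. It relates to compound 3 by thiophen-2-yl in place of furan-2-yl on an aromatic carbon. Going by the values given here, this is the same kind of change as the one from compound 1 to compound 2, but the place is not the same: in compound 1 the furan-2-yl sits on an aromatic carbon of a five-membered aromatic ring with 2 nitrogen and 1 oxygen, between two ring nitrogen atoms, two ring bonds from the ring oxygen, whereas in compound 3 it sits on an aromatic carbon of a five-membered aromatic ring with 2 nitrogen and 1 sulfur, next to the ring nitrogen and next to the ring sulfur.

Among the compounds with values here, the step from compound 3 to compound 4 in this assay is expected to be a 1.5-fold higher number from compound 3 to compound 4 (0.17 log units; within the scatter), a small step beside a 1.6-fold higher number from compound 1 to compound 2 (0.20 log units; within the scatter), because the one measured instance of this change, a 1.6-fold higher number from compound 1 to compound 2 (0.20 log units; within the scatter), stayed within the scatter. Compound 4 is therefore estimated at 11 nM, with a likely range from 5 nM to 25 nM.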

Compound 4, inhibition constant: 27 nM
For compound 4 the middle estimate is 2.5-fold (0.39 log units) below the measured one; measured number above the stated range.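

Carried to the core of compound 3, thiophen-2-yl in place of furan-2-yl gave a 3.6-fold higher number from compound 3 to compound 4 (0.56 log units; beyond the scatter) in this assay, while on the core of compound 1 the same change gave a 1.6-fold higher number from compound 1 to compound 2 (0.20 log units; within the scatter). Set side by side, the two steps cannot be told apart: the same change on two cores in this assay, a 1.6-fold higher number (0.20 log units; within the scatter) from compound 1 to compound 2 and a 3.6-fold higher number (0.56 log units; beyond the scatter) from compound 3 to compound 4, 2.3-fold (0.36 log units) apart, within the scatter of two such steps. Going by these compounds alone, the series therefore gives no evidence that the core alters the effect of this change, but it does not establish that the effect carries over unchanged either, since each core offers only one pair, with one step within the scatter and the other beyond it.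

The compounds shown leave open how this change would behave on any further core, and whether a larger set of pairs would separate the two cores. They also leave open how the values in this assay would respond to other groups on the aromatic carbon that bears furan-2-yl or thiophen-2-yl, such as a phenyl ring, an amine or a carboxylic acid, or to a shorter or longer chain between the carbonyl and the phenyl ring.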